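Trimming a Benzyl Group on a Shared Core

The source may report more compounds than this note shows. Statements on the series, on what has been measured and on what is new or still open speak of the compounds shown alone.

Of the compounds shown here, three have been measured in an ADME assay on HEL cells (Homo sapiens) for cytotoxicity, with a stated time of 3 days; a lower number here means that less compound is tolerated, a higher number that more compound is tolerated. Compound 1 `CCC1(Cc2ccccc2)OS(=O)(=O)C=C1OCC(=O)OC` reaches only a limit of this assay, > 400000 nM. Compound 3 `CCC1(Cc2ccccc2)OS(=O)(=O)C=C1OCc1ccc([N+](=O)[O-])cc1` likewise gives a limit, >= 80000 nM. The step that the two limits leave unreadable from compound 1 to compound 3 thus cannot be read. Within the data shown here, compound 2 `O=S1(=O)C=C(OCc2ccccc2)C(Cc2ccccc2)(Cc2ccccc2)O1` is the only compound with a number: in this assay compound 2 gives 200000 nM. Compound 4 `CC1(Cc2ccccc2)OS(=O)(=O)C=C1OCc1ccccc1` differs from compound 2 by hydrogen in place of phenyl on a saturated chain carbon bound to a saturated ring carbon. Among the measured compounds shown here, no measured step touches this change, and the single measured step is unreadable, so no movement beyond the scatter is expected in this assay. Compound 4 is expected to give about 200000 nM, from 80000 nM to 400000 nM. The expected step is no change at the digits printed from compound 2 to compound 4 (within the scatter).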

Compound 4, minimum cytotoxic concentration: > 400000 nM
Compound 4 was reported as a limit; the forecaster's own chance of this, stated with the estimate: 40%; at least 2.0-fold (0.30 log units) between middle value and limit.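

This is the first readable step among the compounds shown, and it falls on the benzyl group of the shared core: hydrogen in place of phenyl, or benzyl to methyl, gives an at least 2.0-fold higher number from compound 2 to compound 4 (0.30 log units; that floor lies within the scatter) in this assay. Losing that phenyl therefore brings no drop in the tolerated concentration, though the floor of the step alone does not clear the scatter. The reading for compound 4 is a limit, so the full size of the step stays unknown: the limit of > 400000 nM in this assay, at which 2 of the 4 values shown sit.

As far as these compounds go, how a propyl chain or an amine at this place would read in this assay remains open.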